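Swapping the sulfonamide chain for an ester-bearing pyrrolidine

The source may report more compounds than this note shows. Statements on the series, on what has been measured and on what is new or still open speak of the compounds shown alone.

Among the three compounds measured in a functional assay on HCC827 cells (Homo sapiens) for antiproliferative activity, read by MTT assay, with a stated time of 72 h (on this read-out lower numbers stand for stronger inhibition and higher numbers for weaker inhibition), compound 3 `CN1CCN(c2ccc(Nc3ncc4nc(Nc5ccc(F)cc5)n(CCNS(=O)(=O)C5CC5)c4n3)cc2)CC1` gives the lowest number, 50 nM. Compound 1 `CN1CCN(c2ccc(Nc3ncc4nc(Nc5ccc(F)cc5)n([C@@H]5CCN(C(=O)CO)C5)c4n3)cc2)CC1` gives 350 nM and compound 2 `CN1CCN(c2ccc(Nc3ncc4nc(Nc5ccc(F)cc5)n([C@H]5CCNC5)c4n3)cc2)CC1` gives 1220 nM. Compound 4 `CCOC(=O)CN1CC[C@H](n2c(Nc3ccc(F)cc3)nc3cnc(Nc4ccc(N5CCN(C)CC5)cc4)nc32)C1` carries 1-((ethoxycarbonyl)methyl)pyrrolidin-3-yl in place of 2-((cyclopropylsulfonyl)amino)ethyl on an aromatic nitrogen. The measured steps that bear on this change ran the other way: a 7.0-fold lower number from compound 1 to compound 3 (0.85 log units; beyond the scatter) and a 24-fold lower number from compound 2 to compound 3 (1.39 log units; beyond the scatter), each replacing a pyrrolidin-3-yl group with the sulfonamide chain and each lowering the number. Going back to a pyrrolidin-3-yl group, now carrying the ethoxycarbonylmethyl group instead of the hydroxymethylcarbonyl or a free hydrogen, is expected to raise the number by a modest step, an 8.0-fold higher number from compound 3 to compound 4 (0.90 log units; beyond the scatter). Compound 4 is estimated at 400 nM, with a range from 120 nM to 1300 nM.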

Compound 4, half-maximal inhibitory concentration: 1810 nM
Beside the measured number, compound 4's estimate is 4.5-fold (0.66 log units) below it; the measured number lies above the stated range.
By their numbers in this assay, from the lowest: compound 3; then compound 1; then compounds 2 and 4 (each within the scatter of the next).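

The sulfonamide chain holds a large lead over this ester-bearing pyrrolidine, with a 36-fold higher number from compound 3 to compound 4 (1.56 log units; beyond the scatter). On the pyrrolidine's amine nitrogen, (ethoxycarbonyl)methyl and hydrogen cannot be told apart, with a 1.5-fold higher number from compound 2 to compound 4 (0.17 log units; within the scatter), while the (hydroxymethyl)carbonyl group gives the lower number, with a 5.2-fold higher number from compound 1 to compound 4 (0.71 log units; beyond the scatter). Nothing available explains these differences.

Going by these compounds, it remains open whether the lead of compound 3 comes from the cyclopropylsulfonyl group or from the open ethyl chain, and a cyclopropylsulfonyl group on the pyrrolidine nitrogen would help separate the two. Also open, on these data alone, is how a carboxylic acid in place of the ethyl ester would behave.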